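Thiophene carbonyl replaces butyl carbonyl on an acylthiourea benzothiazole

A few compounds are considered here, and "the series" means these few. Any claim that something is new, unique, unknown or untested is made for them only; others in the source may bear on it.

This account follows the step from compound 1 `CCCCC(=O)NC(=S)Nc1nc2cc(N)ccc2s1` to compound 3 `Nc1ccc2sc(NC(=S)NC(=O)c3cccs3)nc2c1`. In a functional assay on HeLa cells (Homo sapiens) for cytotoxicity, read by MTT assay, with a stated time of 24 h (on this read-out higher numbers stand for weaker inhibition and lower numbers for stronger inhibition), compound 1 gives "not determined" (no result reported), so it stands on no number at all, and nothing about it can be placed against the usual scatter. Within the data shown here, the only measured relative is compound 2 `O=C(NC(=S)Nc1nc2cc([N+](=O)[O-])ccc2s1)c1ccccc1`, which in this assay gives 75100 nM; it differs from compound 1 in two places and no step between it and either other compound is available. The change itself is thiophen-2-yl in place of butyl on a carbonyl carbon. Without a measured starting point, no size or direction of step can be stated for compound 3 beyond the scatter. Judging only from the weak value of compound 2 in this assay, compound 3 is expected to fall near 60000 nM, with a likely range from 15000 nM to 250000 nM.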

Compound 3, half-maximal inhibitory concentration: 56100 nM
For compound 3 the middle estimate is 1.1-fold (0.03 log units) above the measured one, and the stated range covers the measured number.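

No step can be read between compound 1 and compound 3: compound 3 stands at 56100 nM while compound 1 has no number. The compounds shown leave open what thiophen-2-yl in place of butyl does to cytotoxicity. No supporting evidence bears on this result.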